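The source may hold more compounds than are shown below. What is called first, only, known or untested is meant among the compounds shown, and "the series" means these compounds.

Working notes on the series.

Three compounds in the series have a number in an ADME assay on microsomes from liver (Homo sapiens) for metabolic stability, read by LC-MS, using NADPH, with a stated time of 30 min, tested at 1 uM; a lower number here means slower removal, a higher number faster removal of the compound. Compound 1 `CC#Cc1cncc(-c2ccc3c(c2)[C@@]2(COC(N)=N2)c2cc(Cl)ncc2O3)c1` gives 27 mL.min-1.g-1. Compound 2 `NC1=N[C@@]2(CO1)c1cc(-c3cncc(C#CCO)c3)ccc1Oc1cnc(C3=CCOCC3)cc12` gives 84 mL.min-1.g-1. Compound 3 `NC1=N[C@@]2(CO1)c1cc(NC(=O)c3ccc(Cl)cn3)ccc1Oc1cnc(Cl)cc12` gives 37 mL.min-1.g-1. On these numbers compound 3 stands second highest of three: its nearest neighbour is compound 1, whose number is within the scatter of it, and the furthest is compound 2, whose number lies beyond the scatter above it. Among the compounds with values here, the single step measured in one place, a 1.4-fold higher number from compound 1 to compound 3 (0.14 log units; within the scatter), is within the scatter and changes a different part of the shared core.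

Compound 4 `NC1=N[C@@]2(CO1)c1cc(NC(=O)c3ccc(Cl)cn3)ccc1Oc1cnc(C3CCOCC3)cc12` is the next compound for this assay. It differs from compound 3 as follows: oxan-4-yl in place of chloro on an aromatic carbon.

Within the data shown here, no measured step changes this same position, so no step bears directly on the move from compound 3 to compound 4. Among the measured compounds shown here, compound 2 is the only compound without chloro at that carbon and gives the highest number of the three, but it differs from the others in a second place as well, so it supports only a weak lean. An increase of modest size is therefore expected, a 1.5-fold higher number from compound 3 to compound 4 (0.17 log units; within the scatter), though a step within the scatter would not be surprising. Compound 4 is estimated at 55 mL.min-1.g-1, with a range from 28 mL.min-1.g-1 to 110 mL.min-1.g-1.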

Compound 4, intrinsic clearance in microsomes: 80 mL.min-1.g-1
For compound 4 the middle estimate is 1.5-fold (0.16 log units) below the measured one; the measured number falls inside the stated range.
By their numbers in this assay, from the lowest: compounds 1 and 3 (each within the scatter of the next); then compounds 4 and 2 (each within the scatter of the next).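

In this assay, oxan-4-yl in place of chloro on the aromatic carbon next to the ring nitrogen gives a 2.2-fold higher number from compound 3 to compound 4 (0.33 log units; beyond the scatter), the first step shown at this position and a modest one in size. Within the data shown here, the only earlier step between compounds that differ in one place, a 1.4-fold higher number from compound 1 to compound 3 (0.14 log units; within the scatter), changes a different position, so this carbon is the first place where a single change is seen to move the number beyond the scatter. The change swaps a single chlorine for a six-membered non-aromatic ring that carries one oxygen, and no measurement available here accounts for the rise or separates the contributions of those features.

Going by these compounds, it remains open whether cyclohexyl, which has no ring oxygen, or an amine such as morpholin-4-yl at the same carbon would give a step of similar size, and so whether the ring oxygen matters to this number. On these data alone, it is also open whether the same exchange of chloro for oxan-4-yl would give a similar step with 5-(prop-1-yn-1-yl)pyridin-3-yl in place of ((5-chloropyridin-2-yl)carbonyl)amino, as in compound 1.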